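Replacing isopropyl with 2-acetamidoethyl on the sulfonyl sulfur

The source may hold more compounds than are shown below. What is called first, only, known or untested is meant among the compounds shown, and "the series" means these compounds.

Three compounds have been run in an ADME assay on microsomes from liver (Rattus norvegicus) for metabolic stability, with a stated time of 10 min; on this read-out higher numbers stand for a more stable compound and lower numbers for a less stable compound. Compound 1 `CC(C)OC(=O)NCCS(=O)(=O)NC(=O)c1ccc(Nc2nc(NC3(c4ccc(Cl)cc4)CC3)nc(OCC(F)(F)F)n2)cc1` gives 73% in this assay. Compound 2 `CCCCCNc1nc(Nc2ccc([N+](=O)[O-])cc2)nc(OCC(F)(F)F)n1`, which shares the core but carries a pentyl and a nitrophenyl group, gives 35%. Compound 3 `CC(C)S(=O)(=O)NC(=O)c1ccc(Nc2nc(NC3(c4ccc(Cl)cc4)CC3)nc(OCC(F)(F)F)n2)cc1` gives 96% and stands highest of the three, with compound 1 the nearest and compound 2 the furthest below it.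

Within the data shown here, the only measured step that changes one place is a number 23 percentage points higher from compound 1 to compound 3 (beyond the scatter), where a longer chain on the sulfonyl sulfur gives way to a smaller isopropyl group and stability rises. Compound 4 `CC(=O)NCCS(=O)(=O)NC(=O)c1ccc(Nc2nc(NC3(c4ccc(Cl)cc4)CC3)nc(OCC(F)(F)F)n2)cc1` has not yet been measured. Its structure differs from compound 3 as follows: 2-acetamidoethyl in place of isopropyl on a sulfonyl sulfur. Among the measured compounds shown here, the group that enters is shorter than the one in compound 1 but, like it, carries a hydrogen-bond donor and acceptor, so compound 4 sits structurally between compound 1 and compound 3.

Because the step of a number 23 percentage points higher from compound 1 to compound 3 (beyond the scatter) was modest and went upward when the chain was removed, a decline of similar or slightly smaller size is expected when a chain returns, so the expected step is a number 16 percentage points lower from compound 3 to compound 4 (beyond the scatter). For compound 4 the estimated value in this assay is 80%, with a range from 62% to 95%.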

Compound 4, percent of the compound remaining: 100%
For compound 4 the middle estimate is 20 percentage points below the measured one, and the stated range ends below it.
By their numbers in this assay, from the lowest: compound 2; then compound 1; then compounds 3 and 4 (each within the scatter of the next).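

In this assay, 2-acetamidoethyl in place of isopropyl on the sulfonyl sulfur gives a number 4 percentage points higher from compound 3 to compound 4 (within the scatter), so this position accepts a longer chain with a hydrogen-bond donor and acceptor without a change that can be told from the scatter. Having a chain on the sulfonyl sulfur therefore does not by itself set the number: methyl in place of isopropoxy on a carbonyl carbon gives a number 27 percentage points higher from compound 1 to compound 4 (beyond the scatter), which shows that among these compounds the lower number of compound 1 goes with the isopropoxy group and not with the chain as a whole. No measurement shown here explains how either change acts on stability in this test.

The compounds shown leave open whether a still longer chain on the sulfonyl sulfur, or a chain ending in an amine or a carboxylic acid, would hold the number as well. They also leave open whether an ethyl or a methoxy group on that carbonyl carbon would behave like the methyl group or like the isopropoxy group.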